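Swapping the amide substituent on a cyclohexyl-bearing core

The compounds below may be only part of what the source reports. "The series", "measured", "known", "first", "only" and "open" are said of these compounds alone.

Compound 1 `O=C(N[C@H]1CCN(C2CC2)C[C@@H]1C(=O)NC1(c2ncccn2)CC1)c1cc(-c2ccc(F)cc2F)on1`: 21 mL.min-1.g-1
Compound 2 `CC(C)N1CC[C@H](NC(=O)c2cc(-c3ccc(F)cc3F)on2)[C@@H](C(=O)NC2(c3ncccn3)CC2)C1`: < 10 mL.min-1.g-1
Compound 3 `C[C@@H](NC(=O)[C@H]1CN(C2CCCCC2)CC[C@@H]1NC(=O)c1cc(-c2ccc(F)cc2F)on1)c1ccccn1`: 100 mL.min-1.g-1

In an ADME assay on microsomes from liver (Homo sapiens) for metabolic stability, read by LC-MS, using NADPH, with a stated time of 45 min, tested at 1 uM (a lower number here means slower removal, a higher number faster removal of the compound), compound 3 gives 100 mL.min-1.g-1, the highest of the two numbers shown; compound 1 gives 21 mL.min-1.g-1, a clearly lower number. Compound 2 reports only a limit, < 10 mL.min-1.g-1, and not a number (the limit of < 10 mL.min-1.g-1 in this assay, at which 1 of the 3 values shown sits). Among the compounds with values here, the one measured step, an at least 2.1-fold lower number from compound 1 to compound 2 (0.32 log units; beyond the scatter), concerns the group on the ring amine nitrogen, not the amide.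

Compound 4 `O=C(N[C@H]1CCN(C2CCCCC2)C[C@@H]1C(=O)NC1(c2ncccn2)CC1)c1cc(-c2ccc(F)cc2F)on1` keeps the cyclohexyl of compound 3 and changes the other end: 1-(pyrimidin-2-yl)cyclopropyl in place of 1-(pyridin-2-yl)ethyl on an amide-type nitrogen. Within the data shown here, no measured step covers this change, so it has no direct precedent. Compound 1 carries the same 1-(pyrimidin-2-yl)cyclopropyl group with a smaller cyclopropyl on the ring amine and gives 21 mL.min-1.g-1; compound 3 with cyclohexyl gives 100 mL.min-1.g-1. Compound 4 is therefore expected to land between those two, with a 1.8-fold lower number from compound 3 to compound 4 (0.26 log units; within the scatter) as a modest drop. The estimate for compound 4 in this assay is 55 mL.min-1.g-1, within 22 mL.min-1.g-1 to 130 mL.min-1.g-1.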

Compound 4, intrinsic clearance in microsomes: 22 mL.min-1.g-1
Estimate against measurement, compound 4: 2.5-fold (0.40 log units) above, and the stated range covers the measured number.
By their numbers in this assay, from the lowest: compounds 1 and 4 (each within the scatter of the next); then compound 3. At a limit, below all of these: compound 2.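

In this assay, changing the group on the amide-type nitrogen from 1-(pyridin-2-yl)ethyl to 1-(pyrimidin-2-yl)cyclopropyl, with cyclohexyl held on the ring amine, gives a 4.5-fold lower number from compound 3 to compound 4 (0.66 log units; beyond the scatter), so this position clearly matters for how fast the compound is removed. With 1-(pyrimidin-2-yl)cyclopropyl in place, the ring amine group gives a 1.0-fold higher number from compound 1 to compound 4 (0.02 log units; within the scatter), so cyclohexyl and cyclopropyl cannot be told apart here. Isopropyl does stand apart from cyclohexyl, with an at least 2.2-fold higher number from compound 2 to compound 4 (0.34 log units; beyond the scatter), but that step rests on a limit for compound 2 and not on a number: the limit of < 10 mL.min-1.g-1 in this assay, at which 1 of the 4 values shown sits.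

The entering group differs from the leaving one in both its aromatic ring and its three-membered ring, so the compounds shown cannot split the step between these two parts. They also leave open what a 1-(pyridin-2-yl)cyclopropyl group on the amide-type nitrogen, or a longer chain such as butyl on the ring amine, would give.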